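This account rests on a few compounds, and the source may have more. Where it says the series, first, only, none or still open, it means among the compounds named here.

Measured in an assay on isolated protein (strain Balb/c) for inhibition of Polyunsaturated fatty acid 5-lipoxygenase (Mus musculus), read by immunoassay, with a stated time of 20 min; on this read-out higher numbers stand for weaker inhibition and lower numbers for stronger inhibition:
Compound 1, `c1ccc(Nc2nc3ccccc3o2)cc1`, gives 8910 nM.
Compound 2, `CCc1ccc(Nc2nc3cc([N+](=O)[O-])ccc3o2)cc1`, gives 23900 nM.
Compound 3, `CCc1ccccc1Nc1nc2cc(C)ccc2o1`, gives 5660 nM.

Compound 1 stands second highest of the three numbers in this assay. Its nearest neighbour is compound 3, whose value lies within the scatter of that of compound 1; compound 2 stands furthest, with a number beyond the scatter above compound 1. For the measured compounds named here, no pair among the measured compounds differs in only one place, so no single-change step is available.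

Compound 4, `COc1ccc2oc(Nc3ccccc3)nc2c1`, differs from compound 1 by methoxy in place of hydrogen on an aromatic carbon. With nothing to anchor the size of this change, no step beyond the scatter is expected in either direction; the expected step from compound 1 to compound 4 is a 1.2-fold lower number from compound 1 to compound 4 (0.07 log units; within the scatter). Compound 4 is estimated at 7500 nM, with a range from 2500 nM to 22000 nM.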

Compound 4, half-maximal inhibitory concentration: 7880 nM
Estimate against measurement, compound 4: 1.1-fold (0.02 log units) below; low and high end bracket the measured number.
By their numbers in this assay, from the lowest: compounds 3, 4 and 1 (each within the scatter of the next); then compound 2.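

For the compounds shown here, the step of a 1.1-fold lower number from compound 1 to compound 4 (0.05 log units; within the scatter) is the first single-change step, and it stays within the scatter. On this aromatic carbon, meta to a fused ring and para to a fused ring, methoxy and hydrogen read alike in this assay. No independent evidence bears on this result.

From the compounds shown here alone, whether an amine, a carboxylic acid or a longer chain such as butoxy on this carbon would also stay within the scatter remains open. So does the outcome for methoxy on the other aromatic carbons of the core of compound 1.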